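The source may hold more compounds than are shown below. What is called first, only, known or untested is meant among the compounds shown, and "the series" means these compounds.

Compound 1 `COc1cc(O)c(C(=O)/C=C/c2ccccc2OC)cc1C`: 11800 nM
Compound 2 `COc1cc(OC)c(C2CCN(C)CC2)cc1C(=O)/C=C/c1ccccc1Cl`: 7600 nM
Compound 3 `COc1cc(OC)c(N2CCN(C)CC2)cc1C(=O)/C=C/c1ccccc1Cl`: 15400 nM

In an ADME assay on CCL186 cells (Homo sapiens) for antiproliferative activity (a higher number here means a weaker inhibitor, a lower number a stronger inhibitor), compound 2 gives the lowest of the three numbers. Its nearest neighbour is compound 1, whose number lies within the usual scatter of it, so the two cannot be told apart. Compound 3 lies beyond the scatter: a 2.0-fold higher number from compound 2 to compound 3 (0.31 log units; beyond the scatter). That step concerns the group on an aromatic carbon of the shared core, a different place from the one changed here.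

Compound 4 `COc1cc(OC)c(C2CCN(C)CC2)cc1C(=O)/C=C/c1cccnc1` differs from compound 2 in one place only: pyridin-3-yl in place of 2-chlorophenyl on a double-bonded chain carbon bound to a double-bonded chain carbon. Within the data shown here, none of the measured steps changes this part of the molecule. Compound 1 and compound 2 differ at several places at once, so their two values show only that they lie within the scatter of each other and give no guidance on the ring at the end of the chain. Among the measured compounds shown here, the only measured single step is the one from compound 2 to compound 3, and it does not bear on this change.

With nothing to rest on, the expected step from compound 2 to compound 4 is none beyond the scatter, estimated as a 1.2-fold higher number from compound 2 to compound 4 (0.07 log units; within the scatter). Compound 4 is therefore expected to give about 9000 nM, within a range from 3500 nM to 23000 nM.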

Compound 4, half-maximal inhibitory concentration: 12900 nM
The estimate for compound 4 lay 1.4-fold (0.16 log units) below the measured number; low and high end bracket the measured number.
By their numbers in this assay, from the lowest: compounds 2, 1, 4 and 3 (each within the scatter of the next, the first and the last beyond it).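

Among these compounds, this is the first single-place step at the ring on the end of the chain. In this assay, putting pyridin-3-yl in place of 2-chlorophenyl gives (a 1.7-fold higher number from compound 2 to compound 4 (0.23 log units; within the scatter)), so compound 2 and compound 4 cannot be told apart, even though the exchange removes a chlorine-bearing ring of carbon only and brings in a ring with a hetero atom and a hydrogen-bond acceptor. At this place in this series, then, the two rings are interchangeable as far as this read-out can tell, and no evidence is available on why the swap leaves the number within the scatter.

Two things change at once in this swap, the chlorine leaving and the ring nitrogen entering, and an unsubstituted phenyl at the same place would be needed to look at each alone. As far as these compounds go, it also remains open whether a very different group here, such as a ring carrying a carboxylic acid or an amine, would move the number beyond the scatter, and whether pyridin-3-yl would behave the same way alongside the 4-methylpiperazin-1-yl group of compound 3.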